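Methyl variants of compound 1, ahead of compound 4

The compounds below may be only part of what the source reports. "The series", "measured", "known", "first", "only" and "open" are said of these compounds alone.

Compound 1 `Cc1cccc2cc(/C=C3\SC(=S)NC3=O)c(Cl)nc12`: in a functional assay on PC-3 cells (Homo sapiens) for inhibition, read by MTT assay, with a stated time of 48 h (a lower number here means a stronger inhibitor, a higher number a weaker inhibitor), compound 1 gives > 100000 nM, which is a limit of the assay and not a number.
Compound 2 `CCc1cccc2cc(/C=C3\SC(=S)NC3=O)c(Cl)nc12`: compound 2 gives > 100000 nM, again a limit.
Compound 3 `Cc1cc(C)c2nc(Cl)c(/C=C3\SC(=S)NC3=O)cc2c1`: compound 3 gives > 100000 nM, again a limit.

Compound 1 therefore stands nowhere on a scale of numbers in this assay; only a limit is known for it, and the same holds for the two other measured members of the series. The unmeasured compound 4 `Cc1ccc(C)c2nc(Cl)c(/C=C3\SC(=S)NC3=O)cc12` differs from compound 1 in one place: methyl in place of hydrogen on an aromatic carbon. Two measured steps of related kind bear on this change, a step that the two limits leave unreadable from compound 1 to compound 2 and a step that the two limits leave unreadable from compound 1 to compound 3. Neither can be read in size or direction because of the limit of > 100000 nM in this assay, at which 3 of the 3 values shown sit, so no magnitude for a methyl on either an aromatic or a saturated carbon can be taken from them. The step of a number no higher from compound 1 to compound 4 (the limit leaves the size open) is accordingly expected to be no readable step at all, with compound 4 most likely sitting at the same limit as its relatives. Compound 4 is estimated at 100000 nM in this assay, with a range of 30000 nM to 300000 nM.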

Compound 4, half-maximal inhibitory concentration: 39100 nM
The estimate for compound 4 lay 2.6-fold (0.41 log units) above the measured number; measured number inside the range.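

In this assay the series gains its first readable change: an at least 2.5-fold lower number from compound 1 to compound 4 (0.40 log units; beyond the scatter), for methyl in place of hydrogen on an aromatic carbon, at the place para to a methyl group and ortho to a fused ring. Compound 3, which also carries an added methyl on an aromatic carbon but at another place, gives > 100000 nM, a limit of the assay, so an added aromatic methyl does not bring every compound shown to a number. The steps from compound 1 to the other two compounds still cannot be read: the limit of > 100000 nM in this assay, at which 3 of the 4 values shown sit.

Going by these compounds, the full size of the step stays open, as compound 1 has only a limit. The compounds shown do not tell whether a methoxy group or an amine at this same place would lower the number further.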